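Swapping Methoxy for Methylsulfanyl on a Second Core

The source may hold more compounds than are shown below. What is called first, only, known or untested is meant among the compounds shown, and "the series" means these compounds.

Measured so far:
compound 1, `CSc1ccc(CNc2nc(SC)nc3ncccc23)cc1`: 50 nM
compound 2, `COc1ccc(CNc2nc(SC)nc3ncccc23)cc1`: 48100 nM
compound 3, `COc1ccc(CNc2nc(SC)nc3ccccc23)cc1`: 30900 nM

Of the compounds shown here, three have been tested in a functional assay on MCF7 cells (Homo sapiens) for cytotoxicity, read by MTT assay, with a stated time of 72 h; a lower number here means a stronger inhibitor of growth, a higher number a weaker inhibitor of growth. In this assay compound 1 gives 50 nM, compound 2 gives 48100 nM, and compound 3 gives 30900 nM.

Compound 2 and compound 1 differ in one place only: methylsulfanyl in place of methoxy on an aromatic carbon. That single change produced a step of a 960-fold lower number from compound 2 to compound 1 (2.98 log units; beyond the scatter), a striking move toward a stronger inhibitor of growth.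

Compound 3 carries the same methoxy group as compound 2 but sits on a different core; the difference between the two cores is not broken down here. In this assay compound 3 and compound 2 give numbers that lie within the scatter of each other, so no difference between them can be claimed.

Compound 4 `CSc1ccc(CNc2nc(SC)nc3ccccc23)cc1` has not yet been measured. It differs from compound 3 as methylsulfanyl in place of methoxy on an aromatic carbon, the same change, at the same place, that separates compound 2 from compound 1. Because the measured step was a 960-fold lower number from compound 2 to compound 1 (2.98 log units; beyond the scatter), a move in the same direction is expected for compound 4. That step rests on one pair alone, and the cores differ, so some caution is warranted. The step expected here is a 390-fold lower number from compound 3 to compound 4 (2.59 log units; beyond the scatter), somewhat smaller than the measured one. Compound 4 is expected to give about 80 nM, with a likely range from 15 nM to 2000 nM.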

Compound 4, concentration for 50% growth inhibition: 47300 nM
Beside the measured number, compound 4's estimate is 590-fold (2.77 log units) below it; the whole stated range lies below it.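

On the core of compound 3, putting methylsulfanyl in place of methoxy gives, in this assay, a 1.5-fold higher number from compound 3 to compound 4 (0.18 log units; within the scatter), so no difference between these two compounds can be claimed. The large step seen on the core of compound 1 therefore does not carry over to the core of compound 3, and the two steps really do differ: the same change on two cores in this assay, a 960-fold lower number (2.98 log units; beyond the scatter) from compound 2 to compound 1 and a 1.5-fold higher number (0.18 log units; within the scatter) from compound 3 to compound 4, 1500-fold (3.17 log units) apart, beyond the scatter of two such steps. Among the compounds shown here, this shows that, for these two pairs, the effect of the swap depends on the core it sits on, but it does not show which feature of the cores is responsible, and with only one pair on each core it gives no rule for predicting the swap on any further core.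

The compounds shown leave open whether the large step on the core of compound 1 is specific to methylsulfanyl, or whether another group in the same place, such as ethylsulfanyl, a dimethylamino group or a chlorine atom, would also separate the two cores. They also leave open whether any such group could give the core of compound 3 a number clearly lower than those of compound 3 and compound 4, which so far lie within the scatter of each other.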